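A few compounds are considered here, and "the series" means these few. Any claim that something is new, unique, unknown or untested is made for them only; others in the source may bear on it.

Compound 1 `CCn1c(NC2CC2)nc2ccsc2c1=O` gives 430 ug/mL
Compound 2 `CCn1c(NC(C)C)nc2c(C3CCN(C(=O)c4ccccc4)C3)csc2c1=O` gives 21 ug/mL

Both numbers come from a physicochemical assay for solubility, in phosphate buffer, at pH 6.8 (on this read-out higher numbers stand for higher solubility and lower numbers for lower solubility), and compound 1 holds the higher of the two, with a gap to compound 2 that lies beyond the usual scatter of repeated measurements. Compound 3 `CCn1c(NC2CCOCC2)nc2ccsc2c1=O` keeps the core of compound 1 and changes one group, with oxan-4-yl in place of cyclopropyl on a nitrogen on an aromatic ring as the whole difference. Among the compounds with values here, no two measured compounds differ in only one place, so the data offer no direct guide to the size or direction of this swap. The expectation is therefore no change beyond the scatter, with an estimated 1.1-fold lower number from compound 1 to compound 3 (0.03 log units; within the scatter) as the step. For compound 3 the estimated value in this assay is 400 ug/mL (expected range 150 ug/mL to 1000 ug/mL).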

Compound 3, solubility: 37 ug/mL
Estimate against measurement, compound 3: 11-fold (1.03 log units) above; the measured number lies below the stated range.
By their numbers in this assay, from the lowest: compounds 2 and 3 (each within the scatter of the next); then compound 1.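

Within the data shown here, this is the first pair here that differs in one place only, so it gives the first direct reading of a change on the nitrogen on an aromatic ring. In this assay, oxan-4-yl in place of cyclopropyl gives a 12-fold lower number from compound 1 to compound 3 (1.07 log units; beyond the scatter), so the group at this place is not a silent passenger: on the core of compound 1, this one swap moves the read-out well beyond the scatter. Nothing measured here explains the drop.

The compounds shown leave open whether the drop follows the oxygen in the ring or the larger ring size, and a cyclohexyl group on the same nitrogen would separate the two. Also open, going by these compounds, is how an amine, such as piperidin-4-yl, or a short open chain would behave at this place.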